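Bromo-bearing urea series: swap of the aryl amide substituent

A few compounds are considered here, and "the series" means these few. Any claim that something is new, unique, unknown or untested is made for them only; others in the source may bear on it.

Compound 1 `O=C(Nc1ccc(F)cc1)Nc1nc(-c2cc3ccccc3o2)cs1` gives 1130 nM in a physicochemical assay, with a stated time of 6 min; on this read-out lower numbers stand for stronger inhibition and higher numbers for weaker inhibition.
Compound 2 `O=C(Nc1ccc(F)cc1)Nc1nc(-c2cc3cc(Br)ccc3o2)cs1` gives in this assay only a limit, > 200000 nM, and no number.
Compound 3 `O=C(Nc1cccc(F)c1)Nc1nc(-c2cc3ccccc3o2)cs1` gives 4520 nM in this assay.

Compound 2 stands at the limit of the read-out (the limit of > 200000 nM in this assay, at which 1 of the 3 values shown sits); its value is not a number, and it is the weakest of the three shown, since the step of an at least 170-fold higher number from compound 1 to compound 2 (2.24 log units; beyond the scatter) is large and beyond the scatter.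

Compound 4 `O=C(Nc1nc(-c2cc3cc(Br)ccc3o2)cs1)Nc1ccccc1[N+](=O)[O-]` differs from compound 2 in one place: 2-nitrophenyl in place of 4-fluorophenyl on an amide-type nitrogen. The bromo on the aromatic carbon of compound 2 is kept.

Within the data shown here, only one measured step touches the group on the amide-type nitrogen: a 4.0-fold higher number from compound 1 to compound 3 (0.60 log units; beyond the scatter), a modest step. Among the measured compounds shown here, nothing measured shows a 2-nitrophenyl at this place, and no step starts from a compound already at the limit. The single aryl change shown moved the number by a modest amount; the bromo change moved it to the limit. The expectation is therefore that compound 4 stays at or near the limit in this assay, with no step beyond the scatter resolvable.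

Compound 4 is expected at 250000 nM, within 50000 nM to 1000000 nM. The expected step that the limit leaves unreadable from compound 2 to compound 4 is thus essentially none, most likely reported again as a limit.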

Compound 4, half-maximal inhibitory concentration: 166000 nM
For compound 4 the middle estimate is 1.5-fold (0.18 log units) above the measured one, and the stated range covers the measured number.
By their numbers in this assay, from the lowest: compound 1; then compound 3; then compound 4. At a limit, above all of these: compound 2.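

In this assay the bromo series now holds a compound with a number, compound 4 at 166000 nM, so the group on the amide-type nitrogen can be followed with the bromo kept, which compound 1 and compound 3 could not show. The step reads an at least 1.2-fold lower number from compound 2 to compound 4 (0.08 log units; that floor lies within the scatter), so 2-nitrophenyl in place of 4-fluorophenyl gives no difference that can be told from the scatter, and any order between these two compounds stays unresolved. This step is only a floor, bounded on one side, and its real size cannot be read: the limit of > 200000 nM in this assay, at which 1 of the 4 values shown sits.

The compounds shown leave open how 2-nitrophenyl behaves on the core of compound 1, so the effect of the bromo and the effect of the aryl change cannot yet be separated on the same group. Also open, going by these compounds, is whether an amine or a carboxylic acid in place of the nitro group on this phenyl ring would give a clearly lower number with the bromo kept.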